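Cytotoxicity notes: aryl variation on a biaryl amide acid

This account rests on a few compounds, and the source may have more. Where it says the series, first, only, none or still open, it means among the compounds named here.

Compound 1 `COc1cccc(-c2ccc(C(=O)N(Cc3cccc(OCCCCCC(=O)O)c3)C(C)C)cc2)c1` and compound 2 `CC(C)N(Cc1cccc(OCCCCCC(=O)O)c1)C(=O)c1ccc(-c2ccc3c(c2)OCCO3)cc1` share one core. In an ADME assay on BJ cells (Homo sapiens) for cytotoxicity, read by CellTiter-Glo and resazurin assay, with a stated time of 72 h (on this read-out higher numbers stand for an effect only at larger amounts of compound and lower numbers for an effect already at smaller amounts), compound 1 gives only a limit of the assay, > 20900 nM. In this assay compound 2 likewise sits at a limit, > 21900 nM. The step that the two limits leave unreadable from compound 1 to compound 2 therefore cannot be read (the limit of > 20900 nM in this assay, at which 1 of the 2 values shown sits, (the limit of > 21900 nM in this assay, at which 1 of the 2 values shown sits)). Compound 3 `CC(C)N(Cc1cccc(OCCCCCC(=O)O)c1)C(=O)c1ccc(-c2cccc(OC(F)(F)F)c2)cc1` differs from compound 2 by 3-(trifluoromethoxy)phenyl in place of 2,3-dihydro-1,4-benzodioxin-6-yl on an aromatic carbon. No readable measured step bears on this change, so the expected step that the limit leaves unreadable from compound 2 to compound 3 is none beyond the scatter, and compound 3 is expected to sit at a limit again. For compound 3 the estimate in this assay is 25000 nM, range 8000 nM to 80000 nM.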

Compound 3, half-maximal effective concentration: > 26000 nM
Compound 3 ended at the assay's limit (the forecaster's own chance of this, stated with the estimate: 70%); at least 1.0-fold (0.01 log units) between middle value and limit.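

For the compounds shown here, compound 1, compound 2 and compound 3 all sit at limits in this assay, and no step among them can be read. The compounds shown leave open at what concentration, if any, each reaches its half-maximal effect.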